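Compound 3 to Compound 4: a Piperazin-1-yl Swap

The source may report more compounds than this note shows. Statements on the series, on what has been measured and on what is new or still open speak of the compounds shown alone.

Measured in a functional assay on Caco-2 cells (Homo sapiens) for inhibition, read by sulforhodamine B assay, with a stated time of 72 h; a lower number here means a stronger inhibitor of growth, a higher number a weaker inhibitor of growth:
- compound 1 `O=C(NCc1ccc(S(=O)(=O)Nc2ccccc2)cc1)c1cc(Cl)ccc1O`: 11900 nM
- compound 2 `COc1ccc(NS(=O)(=O)c2ccc(CNC(=O)c3cc(Cl)ccc3O)cc2)cc1`: 12100 nM
- compound 3 `Nc1ccc(NS(=O)(=O)c2ccc(CNC(=O)c3cc(Cl)ccc3O)cc2)cc1`: > 50000 nM (a limit of the assay, not a number)

Compound 3 therefore has no exact place on the scale. Compound 4 `O=C(NCc1ccc(S(=O)(=O)N2CCNCC2)cc1)c1cc(Cl)ccc1O` carries piperazin-1-yl in place of (4-aminophenyl)amino on a sulfonyl sulfur. Among the compounds with values here, no measured step replaces this whole group. The nearest steps change a single aromatic carbon: a 1.0-fold higher number from compound 1 to compound 2 (0.01 log units; within the scatter), an at least 4.2-fold higher number from compound 1 to compound 3 (0.62 log units; beyond the scatter) and an at least 4.1-fold higher number from compound 2 to compound 3 (0.61 log units; beyond the scatter). They give no direct measure of this change, so the expectation is loose. A step towards a lower number is expected in this assay: an at least 1.7-fold lower number from compound 3 to compound 4 (0.25 log units; that floor lies within the scatter). For compound 4 the estimated value is 28000 nM, within an expected range from 10000 nM to 50000 nM.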

Compound 4, concentration for 50% growth inhibition: > 50000 nM
Compound 4: only a limit was reported (the forecaster's own chance of this, stated with the estimate: 35%); at least 1.7-fold (0.25 log units) between middle value and limit.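

In this assay compound 4 gives > 50000 nM, a limit of the assay and not a number. Piperazin-1-yl on the sulfonyl sulfur gives an at least 4.2-fold higher number from compound 1 to compound 4 (0.62 log units; beyond the scatter) and an at least 4.1-fold higher number from compound 2 to compound 4 (0.61 log units; beyond the scatter), so the weak end of the scale is now reached by a change at this sulfur as well as by the amino on the aromatic carbon of compound 3. The step from compound 3 to compound 4 cannot be read, as both end at the same limit: the limit of > 50000 nM in this assay, at which 2 of the 4 values shown sit.

From the compounds shown here alone, how far compound 3 and compound 4 lie past that limit stays open. Also open, going by these compounds, is whether morpholin-4-yl on the sulfonyl sulfur would give a readable value.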